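A few compounds are considered here, and "the series" means these few. Any claim that something is new, unique, unknown or untested is made for them only; others in the source may bear on it.

Three compounds share one core, a sulfonamide of a cyclic ketone joined to a substituted aromatic ring, and have been measured in a functional assay on HL-60 cells (Homo sapiens) for antiproliferative activity, read by MTT assay, tested at 100 ug/mL; a lower number here means less inhibition, a higher number more inhibition at the concentration tested (going by the name of the read-out). Compound 1, `Cc1ccc(NS(=O)(=O)C2CCCCC2=O)c(C)c1`, gives 12.2%. Compound 3, `Cc1cccc(NS(=O)(=O)C2CCCCC2=O)c1C`, gives 9.38%, a number within the usual scatter of that of compound 1, so the two cannot be told apart. Compound 2, `O=C1CCCCC1S(=O)(=O)Nc1ccc(Cl)cc1C(F)(F)F`, gives 78.6%, far beyond the scatter above both, and it is the only one carrying a chloro and a trifluoromethyl group in place of methyl groups. Compound 1 thus sits among the weakly inhibiting pair.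

Compound 4, `Cc1cc(F)ccc1NS(=O)(=O)C1CCCCC1=O`, differs from compound 1 in one place: fluoro in place of methyl on an aromatic carbon. Within the data shown here, the change is small, one heavy atom swapped for one heavy atom, and no measured pair shows what such a swap does here. Among the measured compounds shown here, a modest step is expected, a number 5.8 percentage points higher from compound 1 to compound 4 (within the scatter), leaning slightly upward only because compound 2, the one compound bearing halogen in place of methyl, gives 78.6%. Compound 4 is expected to give 18%, in a range from 5% to 40%.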

Compound 4, a percentage reported as inhibition, at one concentration (the size of the read-out at that concentration, not a potency): -0.99%
The estimate for compound 4 lay 19 percentage points above the measured number; measured number below the stated range.
By their numbers in this assay, from the lowest: compound 4; then compounds 3 and 1 (each within the scatter of the next); then compound 2.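

In this assay, among these compounds, this is the first pair of compounds that differ in one place, and swapping methyl for fluoro on the aromatic carbon para to a large group gives a number 13.2 percentage points lower from compound 1 to compound 4 (beyond the scatter). The position is therefore not indifferent to what sits on it, and here a halogen does not raise inhibition: compound 4 gives -0.99%, close to no inhibition at the concentration tested. Nothing measured here explains this drop.

The compounds shown leave open how a methoxy group, an amine or a nitrile would behave at this same carbon. They also leave open how much of the high number of compound 2 comes from its chloro and how much from its trifluoromethyl, since it differs from compound 1 in two places.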